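The source may report more compounds than this note shows. Statements on the series, on what has been measured and on what is new or still open speak of the compounds shown alone.

Measured compounds in a functional assay on A549 cells (Homo sapiens) for antiproliferative activity, read by MTT assay, with a stated time of 72 h; on this read-out lower numbers stand for stronger inhibition and higher numbers for weaker inhibition:
compound 1 `COc1cc2ncnc(Nc3ccc(Br)cc3)c2cc1OCCCCC(=O)Nc1ccc(S(N)(=O)=O)cc1`, with a value of > 40000 nM, which is a limit of the assay and not a number.
compound 2 `COc1cc2ncnc(Nc3cccc(C)c3)c2cc1OCCCCC(=O)Nc1ccc(S(N)(=O)=O)cc1`, with a value of 16000 nM.

Compound 2 carries the only number shown in this assay; the one further value shown is a limit. Among the compounds with values here, the step of an at least 2.5-fold lower number from compound 1 to compound 2 (0.39 log units; beyond the scatter) is the only measured step, and its starting end rests on (the limit of > 40000 nM in this assay, at which 1 of the 2 values shown sits), so its true size is known only as a lower bound.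

Compound 3 `COc1cc2ncnc(Nc3ccc(C)cc3)c2cc1OCCCCC(=O)Nc1ccc(S(N)(=O)=O)cc1` is not yet measured. It differs from compound 2 by 4-methylphenyl in place of 3-methylphenyl on a nitrogen on an aromatic ring. Within the data shown here, no measured step compares 3-methylphenyl with 4-methylphenyl on this nitrogen; the one measured step exchanges a bromo-substituted ring for a methyl-substituted one and so does not bear directly on the change from compound 2 to compound 3. With no step of this kind shown, the expected step of a 1.3-fold higher number from compound 2 to compound 3 (0.10 log units; within the scatter) is none beyond the scatter. Compound 3 is therefore estimated at 20000 nM in this assay, expected to fall between 6000 nM and 60000 nM, with a fair chance that only a limit is reported.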

Compound 3, half-maximal inhibitory concentration: > 40000 nM
Compound 3 ended at the assay's limit; the forecaster's own chance of this, stated with the estimate: 30%; at least 2.0-fold (0.30 log units) between middle value and limit.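

In this assay, within the data shown here, going from 3-methylphenyl to 4-methylphenyl on a nitrogen on an aromatic ring gives an at least 2.5-fold higher number from compound 2 to compound 3 (0.39 log units; beyond the scatter), so the place of the methyl on this ring counts even though the two groups have the same heavy atoms and the same donor and acceptor counts, and compound 2 remains the only compound with a number, 16000 nM. The true size of this step is known only as a lower bound because compound 3 gives a limit and not a number: the limit of > 40000 nM in this assay, at which 2 of the 3 values shown sit. The step between compound 1 and compound 3, methyl in place of bromo on an aromatic carbon, cannot be read, as both ends are limits, so these two groups cannot be ranked in this position.

Still open, going by these compounds, is whether the effect belongs to the methyl alone or also holds for other groups on this ring, such as a chloro or methoxy group, and where an unsubstituted phenyl would fall. Also open, on these data alone, is whether the low activity of the series changes with a shorter or longer chain in the link to the amide, or with an amine in place of the sulfonamide.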